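The source may hold more compounds than are shown below. What is called first, only, known or untested is meant among the compounds shown, and "the series" means these compounds.

Measured so far in an assay on HT-29 cells for inhibition of Serine-protein kinase ATM (Homo sapiens), read by fluorescence, with a stated time of 1 h; on this read-out lower numbers stand for stronger inhibition and higher numbers for weaker inhibition:
- compound 1 `CCC(CC)CNc1c(C(N)=O)cnc2ccc(-c3cccnc3)cc12`: 73 nM
- compound 2 `NC(=O)c1cnc2ccc(-c3cccnc3)cc2c1NC1CCCC1`: 137 nM
- compound 3 `C[C@@H](Nc1c(C(N)=O)cnc2ccc(-c3cccnc3)cc12)C1CCOCC1`: 730 nM

Compound 3 stands at the highest number of the three in this assay. The nearer gap is a 5.3-fold higher number from compound 2 to compound 3 (0.73 log units; beyond the scatter), and the wider gap is a 10-fold higher number from compound 1 to compound 3 (1.00 log units; beyond the scatter). Compound 1 and compound 2 sit closer together, with a 1.9-fold higher number from compound 1 to compound 2 (0.27 log units; within the scatter).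

Compound 4 `CCC(CC)COc1c(C(N)=O)cnc2ccc(-c3cccnc3)cc12` is the next one to be measured. The change from compound 3 is 2-ethylbutoxy in place of (1-(oxan-4-yl)ethyl)amino on an aromatic carbon. Two things move at once. The chain that enters is the same 2-ethylbutyl chain that compound 1 carries, and on that count the relevant measured step is a 10-fold higher number from compound 1 to compound 3 (1.00 log units; beyond the scatter), which runs in the opposite direction to the step now taken. Among the compounds with values here, the second part of the change, the switch from an amino link to an oxygen link on the aromatic carbon, is covered by no measured pair; nothing here tells whether it adds to, cancels or leaves unchanged what the chain does.

The expectation for compound 4 is therefore a lower number than compound 3 in this assay, with a step of about a 2.9-fold lower number from compound 3 to compound 4 (0.47 log units; beyond the scatter), but short of a full return to the value of compound 1 and with a wide range. The estimate for compound 4 is 250 nM, with a range from 50 nM to 1500 nM.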

Compound 4, half-maximal inhibitory concentration: > 30000 nM
Compound 4: only a limit was reported; the forecaster's own chance of this, stated with the estimate: 5%; middle value at least 120-fold (2.07 log units) away from the limit.
By their numbers in this assay, from the lowest: compounds 1 and 2 (each within the scatter of the next); then compound 3. At a limit, above all of these: compound 4.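

In this assay, with the 2-ethylbutyl chain held constant, an oxygen link in place of the nitrogen link on this aromatic carbon, ortho to the carbamoyl group, gives an at least 410-fold higher number from compound 1 to compound 4 (2.61 log units; beyond the scatter). The steps from the other two amino compounds run the same way, an at least 210-fold higher number from compound 2 to compound 4 (2.34 log units; beyond the scatter) and an at least 41-fold higher number from compound 3 to compound 4 (1.61 log units; beyond the scatter), and both exceed the widest gap among the three amino side chains, which is a 10-fold higher number from compound 1 to compound 3 (1.00 log units; beyond the scatter); the link atom at this position therefore weighs more here than the choice of side chain among those shown. Compound 4 is reported only as a limit of the assay, and every step to it carries that limit: the limit of > 30000 nM in this assay, at which 1 of the 4 values shown sits.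

As far as these compounds go, the series holds only the amino and oxygen links, so it remains open whether the amino hydrogen or the link atom itself is what matters, a question that a methylated tertiary amine link or a sulfur or methylene link would address. Also open, from the compounds shown here alone, is how an oxygen link behaves with cyclopentyl or 1-(oxan-4-yl)ethyl in place of the 2-ethylbutyl chain.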